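Acetylation of a ring hydroxyl in a lactone series

This account rests on a few compounds, and the source may have more. Where it says the series, first, only, none or still open, it means among the compounds named here.

Measured compounds:
compound 1 `C=C1C(=O)O[C@]2(C)CC[C@@H]1C[C@H](O)[C@@]1(C)CC[C@H](O1)[C@](C)(O)CC[C@H]2OC(C)=O` — > 20 ug/mL in a functional assay on HeLa cells (Homo sapiens) for cytotoxicity (on this read-out lower numbers stand for stronger inhibition and higher numbers for weaker inhibition), a limit of the assay
compound 2 `C=C1C(=O)O[C@]2(C)CC[C@@H]1C[C@H](OC(C)=O)[C@@]1(C)CC[C@H](O1)[C@](C)(O)CC[C@H]2OC(C)=O` — > 20 ug/mL, a limit of the assay
compound 3 `C=C1C(=O)O[C@]2(C)CC[C@@H]1C[C@H](O)[C@@]1(C)CC[C@H](O1)[C@](C)(O)CCC2=O` — > 20 ug/mL, a limit of the assay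

The change from compound 1 to compound 2 is acetyl in place of hydrogen on an oxygen on a saturated carbon. Its step, a step that the two limits leave unreadable from compound 1 to compound 2, cannot be sized, because of the limit of > 20 ug/mL in this assay, at which 3 of the 3 values shown sit. Compound 3 differs from compound 1 in more than one place; the difference between the two cores is not broken down here.

Compound 4 `C=C1C(=O)O[C@]2(C)CC[C@@H]1C[C@H](OC(C)=O)[C@@]1(C)CC[C@H](O1)[C@](C)(O)CCC2=O` is the unmeasured partner of compound 3 and carries the same change, (acetyl in place of hydrogen on an oxygen on a saturated carbon), at a place described word for word as for the pair compound 1 to compound 2.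

With the earlier step unreadable, the expected step that the limit leaves unreadable from compound 3 to compound 4 is taken as flat, which is an estimate resting on compound 3 because compound 3 sits at > 20 ug/mL and the matching acetylation left compound 2 at a limit as well. Compound 4 is therefore expected at 40 ug/mL, with a range from 15 ug/mL to 120 ug/mL, most likely reported again as a limit.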

Compound 4, half-maximal inhibitory concentration: > 20 ug/mL
Compound 4: no number, only a limit; the forecaster's own chance of this, stated with the estimate: 85%; the middle value is on the limit's open side.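

In this assay compound 4 gives > 20 ug/mL, a limit of the assay. No size can be read for the step from compound 3 to compound 4, because both compounds sit at the same limit: the limit of > 20 ug/mL in this assay, at which 4 of the 4 values shown sit.

The compounds shown leave open whether hydroxy to acetoxy changes the read-out on either core.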